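One More Ring Swap on a Shared Core

The source may report more compounds than this note shows. Statements on the series, on what has been measured and on what is new or still open speak of the compounds shown alone.

In a functional assay on HeLa cells (Homo sapiens) for cytotoxicity, read by ELISA, with a stated time of 2 days (on this read-out higher numbers stand for weaker inhibition and lower numbers for stronger inhibition), compound 1 `Oc1ccc(-c2cc(-c3ccccc3)cc(-c3ccsc3)n2)cc1` gives 17300 nM, compound 2 `Oc1ccc(-c2cc(-c3ccccc3)cc(-c3ccco3)n2)cc1` gives 10900 nM and compound 3 `Oc1ccc(-c2cc(-c3ccccc3)cc(-c3cccnc3)n2)cc1` gives 13600 nM. These three compounds differ in a single ring group on a shared core, and their numbers all lie within the usual scatter of one another, so compound 3 is not set apart from the other two.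

Compound 4 `Oc1ccc(-c2cc(-c3ccccc3)cc(-c3ccc(O)cc3)n2)cc1` has not yet been measured. It carries 4-hydroxyphenyl in place of the pyridin-3-yl of compound 3, on the carbon next to the ring nitrogen: 4-hydroxyphenyl in place of pyridin-3-yl on an aromatic carbon.

Three measured swaps at this same place bear on the change: a 1.6-fold lower number from compound 1 to compound 2 (0.20 log units; within the scatter), a 1.3-fold lower number from compound 1 to compound 3 (0.10 log units; within the scatter) and a 1.2-fold higher number from compound 2 to compound 3 (0.10 log units; within the scatter). All three stay within the scatter. None of them brings in 4-hydroxyphenyl, so they offer only an indirect guide. On that evidence, no step beyond the scatter is expected in this assay. The expected change is a 1.1-fold lower number from compound 3 to compound 4 (0.05 log units; within the scatter). Compound 4 is estimated at 12000 nM, with an expected range of 5000 nM to 25000 nM.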

Compound 4, half-maximal inhibitory concentration: 3300 nM
For compound 4 the middle estimate is 3.6-fold (0.56 log units) above the measured one; the measured number lies below the stated range.
By their numbers in this assay, from the lowest: compound 4; then compounds 2, 3 and 1 (each within the scatter of the next).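

At this position the ring group can matter after all: in this assay, 4-hydroxyphenyl gives a 4.1-fold lower number from compound 3 to compound 4 (0.62 log units; beyond the scatter), a 3.3-fold lower number from compound 2 to compound 4 (0.52 log units; beyond the scatter) and a 5.2-fold lower number from compound 1 to compound 4 (0.72 log units; beyond the scatter), each beyond the scatter, whereas the three earlier rings could not be told apart. Compared with pyridin-3-yl, the entering group has a ring of carbon only and also brings a hydrogen-bond donor, and this single step cannot separate those two changes. No measurement is available here to explain the step.

Whether the hydroxy group alone accounts for the step stays open, as the compounds shown include no plain phenyl at this place to compare with compound 4. They also leave open how an amine or a methoxy group on that same ring would compare.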